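This account rests on a few compounds, and the source may have more. Where it says the series, first, only, none or still open, it means among the compounds named here.

Measured so far in an assay for inhibition of Fatty-acid amide hydrolase 1 (Rattus norvegicus), using a Dixon plot; on this read-out lower numbers stand for stronger inhibition and higher numbers for weaker inhibition: compound 1 `CSCc1ccc(-c2cnc(C(=O)CCCCCCc3ccccc3)o2)nc1` with 11.1 nM, and compound 2 `N#C/C=C/c1ccc(-c2cnc(C(=O)CCCCCCc3ccccc3)o2)nc1` with 2.1 nM.

In this assay compound 2 holds the lower of the two numbers, and its nearest neighbour is compound 1 by a 5.3-fold lower number from compound 1 to compound 2 (0.72 log units; beyond the scatter). Compound 3 `C[S+]([O-])/C=C/c1ccc(-c2cnc(C(=O)CCCCCCc3ccccc3)o2)nc1` differs from compound 2 by a group of 3 heavy atoms (1 carbon, 1 oxygen, 1 sulfur; no ring) in place of a group of 2 heavy atoms (1 carbon, 1 nitrogen; no ring), on a double-bonded chain carbon bound to a double-bonded chain carbon. Going by the values given here, the only measured step that touches this part of the shared core is a 5.3-fold lower number from compound 1 to compound 2 (0.72 log units; beyond the scatter), a modest shift, and no step for the incoming group itself exists. For compound 3 the expected step is therefore a 2.4-fold higher number from compound 2 to compound 3 (0.38 log units; beyond the scatter), a small rise. In this assay compound 3 is estimated at 5 nM, within a range from 1.5 nM to 20 nM.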

Compound 3, inhibition constant: 3 nM
Beside the measured number, compound 3's estimate is 1.7-fold (0.22 log units) above it, and the stated range covers the measured number.
By their numbers in this assay, from the lowest: compounds 2 and 3 (each within the scatter of the next); then compound 1.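

In this assay, a sulfur- and oxygen-bearing group in place of cyano on a double-bonded chain carbon leaves the number within the scatter (a 1.4-fold higher number from compound 2 to compound 3 (0.15 log units; within the scatter)), so two different end groups are not told apart at this position. Compound 3 also keeps a clear edge over the (methylsulfanyl)methyl group (a 3.7-fold lower number from compound 1 to compound 3 (0.57 log units; beyond the scatter)), as compound 2 does. No supporting measurement bears on why these groups read alike.

Going by these compounds, whether a carboxylic acid, an amine or a longer chain on the same carbon would also fit remains open. So does the result for a saturated link in place of the double-bonded chain carbons.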